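Chloro to methoxy at the aryl end of the enone

The source may hold more compounds than are shown below. What is called first, only, known or untested is meant among the compounds shown, and "the series" means these compounds.

Three compounds of this series have been run in a functional assay on the whole organism (strain albino) for inhibition, with Rattus norvegicus as the target, read by paw edema, with stated times of 30 min and 2 h, at a dose of 100 mg/kg by the oral route; a higher number here means more inhibition at the dose given (going by the name of the read-out), a lower number less inhibition. Compound 3 `CC(O[N+](=O)[O-])C(=O)Nc1ccc(C(=O)/C=C/c2ccc(Cl)cc2)cc1` gives 55%, the highest of the three numbers; compound 1 `COc1ccc(/C=C/C(=O)c2ccc(NC(=O)CO[N+](=O)[O-])cc2)cc1` gives 49%, within the scatter of compound 3, and compound 2 `COc1ccc(/C=C/C(=O)c2ccc(NC(=O)C(C)Br)cc2)cc1` gives 40%, beyond it. For the measured compounds named here, the one single-point step so far, a number 9 percentage points lower from compound 1 to compound 2 (within the scatter), concerns the amide side, not the aryl end. Compound 4 `COc1ccc(/C=C/C(=O)c2ccc(NC(=O)C(C)O[N+](=O)[O-])cc2)cc1` differs from compound 3 by methoxy in place of chloro on an aromatic carbon. Going by the values given here, no measured step touches this position, so no shift beyond the scatter is expected; the step of a number 5 percentage points lower from compound 3 to compound 4 (within the scatter) is an estimate only. Compound 4 is expected to give 50%, between 36% and 64%.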

Compound 4, a percentage reported as inhibition, in the whole organism at one dose (the size of the read-out at that dose, not a potency): 46%
Compound 4: the middle estimate sits 4 percentage points above what was measured; measured number inside the range.
By their numbers in this assay, from the lowest: compounds 2, 4, 1 and 3 (each within the scatter of the next, the first and the last beyond it).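

In this assay, the first step read at the aryl end, 4-chlorophenyl to 4-methoxyphenyl, gives a number 9 percentage points lower from compound 3 to compound 4 (within the scatter). On the amide side, nitrooxy in place of bromo gives a number 6 percentage points higher from compound 2 to compound 4 (within the scatter), and methyl in place of hydrogen gives a number 3 percentage points lower from compound 1 to compound 4 (within the scatter), so no single change read so far moves the number beyond the scatter. No evidence on the origin of these steps is available.

From the compounds shown here alone, whether an amine or a carboxylic acid at the aryl end would shift the number beyond the scatter remains open. So does the effect of a longer chain on the amide side.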